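This account rests on a few compounds, and the source may have more. Where it says the series, first, only, none or still open, it means among the compounds named here.

Compound 3 `S=c1oc(-c2ccc3c(c2)OCCO3)nn1CN1CCN(c2ccccc2Cl)CC1` is one of three measured members of a family built on a shared core. In a functional assay on BGC-823 cells (Homo sapiens) for antiproliferative activity, read by MTT assay, with a stated time of 48 h (on this read-out higher numbers stand for weaker inhibition and lower numbers for stronger inhibition), compound 3 gives > 50000 nM, which is a limit of the assay and not a number. Compound 1 `S=c1oc(-c2ccc3c(c2)OCCO3)nn1CN1CCN(c2ccc(Cl)cc2)CC1` gives > 50000 nM, likewise a limit. Compound 2 `S=c1oc(-c2ccc3c(c2)OCCO3)nn1CN1CCN(c2ccccn2)CC1` gives 25900 nM. Of the measured steps, an at least 1.9-fold higher number from compound 2 to compound 3 (0.28 log units; that floor lies within the scatter) and an at least 1.9-fold lower number from compound 1 to compound 2 (0.28 log units; that floor lies within the scatter) can be read, whereas a step that the two limits leave unreadable from compound 1 to compound 3. Compound 4 `S=c1oc(-c2ccc3c(c2)OCCO3)nn1CN1CCN(c2cccc(Cl)c2Cl)CC1` differs from compound 3 by chloro in place of hydrogen on an aromatic carbon. Within the data shown here, no measured step adds a chloro on this ring, so the expectation leans on (the limit of > 50000 nM in this assay, at which 2 of the 3 values shown sit). Compound 4 is therefore expected to remain near that limit, the estimated step being a number no higher from compound 3 to compound 4 (the limit leaves the size open). The estimate for compound 4 is 50000 nM, between 20000 nM and 120000 nM.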

Compound 4, half-maximal inhibitory concentration: 22600 nM
The estimate for compound 4 lay 2.2-fold (0.34 log units) above the measured number, within the range that was stated.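

Adding a second chloro, which turns 2-chlorophenyl into 2,3-dichlorophenyl, gives in this assay an at least 2.2-fold lower number from compound 3 to compound 4 (0.34 log units; beyond the scatter), the first sign that a chloro on this ring can strengthen inhibition. A chlorinated phenyl ring can therefore sit level with pyridin-2-yl, as a 1.1-fold lower number from compound 2 to compound 4 (0.06 log units; within the scatter) shows, and 2,3-dichlorophenyl also improves on 4-chlorophenyl, with an at least 2.2-fold lower number from compound 1 to compound 4 (0.34 log units; beyond the scatter). Two of these steps start from a limit of the assay, not a number: the limit of > 50000 nM in this assay, at which 2 of the 4 values shown sit.

As far as these compounds go, whether the chloro must sit on this particular carbon remains open. So does the effect of a methyl or a methoxy group in its place.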